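Cyclohexylamino to benzylamino on the shared core

The compounds below may be only part of what the source reports. "The series", "measured", "known", "first", "only" and "open" are said of these compounds alone.

Within the data shown here, compound 1 `Cc1cc(C)cc(Cn2c(=O)cc(NC3CCCCC3)n(Cc3ccccc3)c2=O)c1` is the only member of the series with a number in an ADME assay on MT4 cells (Homo sapiens) for cytotoxicity, read by MTT assay, with a stated time of 4 days; on this read-out lower numbers stand for higher toxicity in this test and higher numbers for lower toxicity in this test. In this assay compound 1 gives 74000 nM. Compound 2 `Cc1cc(C)cc(Cn2c(=O)cc(N)n(CC#N)c2=O)c1` is reported only as a limit of the assay and not as a number: in this assay compound 2 gives > 100000 nM. This is the limit of > 100000 nM in this assay, at which 1 of the 2 values shown sits. Among the measured compounds shown here, no step between two measured compounds is available, so the series offers no measured size for any single change. Compound 3 `Cc1cc(C)cc(Cn2c(=O)cc(NCc3ccccc3)n(Cc3ccccc3)c2=O)c1` differs from compound 1 by benzyl in place of cyclohexyl on a nitrogen on an aromatic ring. The step of a 1.1-fold lower number from compound 1 to compound 3 (0.02 log units; within the scatter) is expected to stay within the scatter of repeated measurements, with no direction favoured. For compound 3 the estimate in this assay is 70000 nM, with a range from 30000 nM to 150000 nM.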

Compound 3, half-maximal cytotoxic concentration: > 100000 nM
Compound 3: a limit, no number; the forecaster's own chance of this, stated with the estimate: 35%; middle value at least 1.4-fold (0.15 log units) from the limit.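

In this assay compound 3 gives > 100000 nM, which is a limit of the assay and not a number. Benzyl in place of cyclohexyl on a nitrogen on an aromatic ring gives the first step at this position, an at least 1.3-fold higher number from compound 1 to compound 3 (0.13 log units; that floor lies within the scatter), and this is a floor, so the true size of the step stays unknown and no real change can be claimed from it. Swapping one carbon ring for the other thus leaves the read-out at the top of its range, where the series now gathers: the limit of > 100000 nM in this assay, at which 2 of the 3 values shown sit.

Going by these compounds, how far the number of compound 3 lies from that of compound 1 remains open. Also open, on these data alone, is whether phenethylamino, or a carboxylic acid carried on the same nitrogen, would move the read-out at this place in either direction.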